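A few compounds are considered here, and "the series" means these few. Any claim that something is new, unique, unknown or untested is made for them only; others in the source may bear on it.

Going by the values given here, compound 3 `COc1cc(Cl)cc(-c2c(C)nn(-c3nc(-c4ccc(Cl)c(Cl)c4)c(SC(C)C)s3)c2C(=O)O)c1` gives 760 nM in a functional assay on BJAB cells (Homo sapiens) for antiproliferative activity, with a stated time of 4 days (a higher number here means that more compound is needed for the effect, a lower number that less compound is needed), the second highest of the three numbers measured so far. Compound 2 `Cc1cc(-c2c(C)nn(-c3nc(-c4ccc(Cl)c(Cl)c4)c(SC(C)C)s3)c2C(=O)O)cc(C)n1` gives 580 nM, and compound 1 `Cc1cc(C)cc(-c2c(C)nn(-c3nc(-c4ccc(Cl)c(Cl)c4)c(SC(C)C)s3)c2C(=O)O)c1` gives 2700 nM. Compound 4 `Cc1nn(-c2nc(-c3ccc(Cl)c(Cl)c3)c(SC(C)C)s2)c(C(=O)O)c1Cc1ccccc1[N+](=O)[O-]` differs from compound 3 in one place: 2-nitrobenzyl in place of 3-chloro-5-methoxyphenyl on an aromatic carbon. Among the compounds with values here, no measured step exchanges an aromatic group for a benzyl group, so the closest guides are the aromatic exchanges a 4.7-fold lower number from compound 1 to compound 2 (0.67 log units; beyond the scatter) and a 3.6-fold lower number from compound 1 to compound 3 (0.55 log units; beyond the scatter), both modest, whereas a 1.3-fold higher number from compound 2 to compound 3 (0.12 log units; within the scatter) stayed within the scatter. A modest step in this assay is therefore expected for compound 4, its direction uncertain but leaning toward a higher number. The estimate for compound 4 is 1500 nM, within a range from 400 nM to 6000 nM. This expected value means a 2.0-fold higher number from compound 3 to compound 4 (0.30 log units; within the scatter).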

Compound 4, half-maximal effective concentration: 20000 nM
For compound 4 the middle estimate is 13-fold (1.12 log units) below the measured one; measured number above the stated range.
By their numbers in this assay, from the lowest: compounds 2 and 3 (each within the scatter of the next); then compound 1; then compound 4.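

In this assay this position proves much less tolerant than the exchanges among directly attached aromatic groups had shown: 2-nitrobenzyl gives a 26-fold higher number from compound 3 to compound 4 (1.42 log units; beyond the scatter) and a 34-fold higher number from compound 2 to compound 4 (1.54 log units; beyond the scatter). Even from the 3,5-dimethylphenyl compound the change gives a 7.4-fold higher number from compound 1 to compound 4 (0.87 log units; beyond the scatter), so all three directly attached aromatic groups stand below the 2-nitrobenzyl compound. Nothing available explains this loss. Going by these compounds, compound 4 brings the methylene link and the nitro group together, so which of them governs the change stays open; a plain benzyl group or a 3-chloro-5-methoxybenzyl group would separate the two.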